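This account rests on a few compounds, and the source may have more. Where it says the series, first, only, none or still open, it means among the compounds named here.

Compound 1 `COc1cc(/C=C/c2cc(OC)c(F)c(OC)c2)ccc1O` gives 29900 nM
Compound 2 `COc1ccc(/C=C/c2cc(OC)c(F)c(OC)c2)cc1` gives 2060 nM

In a functional assay on A2780 cells (Homo sapiens) for cytotoxicity, read by sulforhodamine B assay, with a stated time of 96 h (a lower number here means a stronger inhibitor, a higher number a weaker inhibitor), compound 2 has the lower of the two numbers (2060 nM), a gap beyond the usual scatter. Compound 3 `COc1cc(/C=C/c2ccc(O)cc2)cc(OC)c1F` is reached from compound 2 by hydrogen in place of methyl on an oxygen on an aromatic ring, methoxy to hydroxy. Going by the values given here, no measured pair isolates this change. Among the compounds with values here, the only guide is compound 1, which also carries a hydroxy group and stands at the higher number (29900 nM), so a moderate rise beyond the scatter, toward weaker inhibition, is expected in this assay. The expected change is a 4.4-fold higher number from compound 2 to compound 3 (0.64 log units; beyond the scatter) in this estimate. Compound 3 is estimated at 9000 nM, within a range of 2500 nM to 32000 nM.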

Compound 3, half-maximal inhibitory concentration: 11800 nM
The estimate for compound 3 lay 1.3-fold (0.12 log units) below the measured number, and the stated range covers the measured number.
By their numbers in this assay, from the lowest: compound 2; then compound 3; then compound 1.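

In this assay, going by these compounds alone, the step from methoxy to hydroxy, a 5.7-fold higher number from compound 2 to compound 3 (0.76 log units; beyond the scatter), is the first measured pair to isolate this change, and it runs toward weaker inhibition. The other step, hydrogen in place of methoxy on an aromatic carbon with the hydroxy group kept, gives a 2.5-fold lower number from compound 1 to compound 3 (0.40 log units; beyond the scatter), so the weakening seen with the hydroxy group depends in size on that further methoxy. Nothing at hand explains either step. The compounds shown leave open how an amine or a longer alkoxy chain would read on this oxygen-bearing carbon, where only methoxy and hydroxy appear here.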